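The source may hold more compounds than are shown below. What is called first, only, known or untested is meant among the compounds shown, and "the series" means these compounds.

Measured so far in an assay for inhibition of Fatty-acid amide hydrolase 1 (Rattus norvegicus); a higher number here means a weaker inhibitor, a lower number a stronger inhibitor: compound 1 `CNC(=O)c1cnc(C(=O)CCc2ccc(COc3ccccc3)cc2)o1` gives 3.6 nM; compound 2 `CNC(=O)c1cnc(C(=O)CCc2ccc(Oc3ccccc3)cc2)o1` gives 11 nM; compound 3 `COC(=O)c1ccc(-c2cnc(C(=O)CCc3ccc(-c4ccccc4)cc3)o2)cn1` gives 0.6 nM.

Among these three, compound 2 has the highest number, so it is the weakest inhibitor of the set; the step of a 3.1-fold higher number from compound 1 to compound 2 (0.49 log units; beyond the scatter) is the only single-point change measured here. Compound 4 `N#Cc1cnc(C(=O)CCc2ccc(Oc3ccccc3)cc2)o1` differs from compound 2 by cyano in place of methylcarbamoyl on an aromatic carbon. Among the measured compounds shown here, no measured step touches this position of the shared core, so nothing here tells how large a change to expect, or in which direction. In the absence of such evidence, compound 4 is estimated to land near compound 2 in this assay, at 7 nM, within 1.5 nM to 30 nM, that is a step of a 1.6-fold lower number from compound 2 to compound 4 (0.20 log units; within the scatter) that may well lie within the scatter.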

Compound 4, inhibition constant: 0.8 nM
For compound 4 the middle estimate is 8.8-fold (0.94 log units) above the measured one; the whole stated range lies above it.
By their numbers in this assay, from the lowest: compounds 3 and 4 (each within the scatter of the next); then compound 1; then compound 2.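

In this assay this position, on the aromatic carbon next to the ring oxygen, has a strong hold on the result: cyano in place of methylcarbamoyl gives a 14-fold lower number from compound 2 to compound 4 (1.14 log units; beyond the scatter) on the shared core. The methylcarbamoyl group, with its hydrogen-bond donor and larger count of heavy atoms, is therefore not needed for strong inhibition. No measurement available here explains this gain. Still open, going by these compounds, is how a carboxylic acid or a primary amide at this position would compare with cyano. Also open, on these data alone, is whether cyano brings a similar gain alongside the phenoxymethyl group of compound 1.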